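Aryl amide in place of a chloroalkyl urea

The source may report more compounds than this note shows. Statements on the series, on what has been measured and on what is new or still open speak of the compounds shown alone.

Measured compounds:
- compound 1, `COCC(=O)Nc1c(C(O)(C(F)(F)F)C(F)(F)F)ccc2ccccc12`, in an assay on LtK cells with ATP-sensitive inward rectifier potassium channel 11 (Homo sapiens) as the target (a lower number here means that less compound is needed, a higher number that more compound is needed for the effect), gives 213 nM
- compound 2, `O=C(NCCCCCCCl)Nc1c(C(O)(C(F)(F)F)C(F)(F)F)ccc2ccccc12`, in this assay gives 4840 nM
- compound 3, `O=C(Nc1c(C(O)(C(F)(F)F)C(F)(F)F)ccc2ccccc12)c1cccc(Br)c1`, in this assay gives 80 nM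

Among these three numbers compound 2 stands highest, and both other compounds lie well apart from it: the step of a 23-fold higher number from compound 1 to compound 2 (1.36 log units; beyond the scatter) and the step of a 61-fold lower number from compound 2 to compound 3 (1.78 log units; beyond the scatter) are each beyond the scatter. The unmeasured compound 4, `O=C(Nc1c(C(O)(C(F)(F)F)C(F)(F)F)ccc2ccccc12)c1ccc(OC(F)(F)F)cc1`, is reached from compound 2 by one change: 4-(trifluoromethoxy)phenyl in place of (6-chlorohexyl)amino on a carbonyl carbon

The step that bears most directly on this change is a 61-fold lower number from compound 2 to compound 3 (1.78 log units; beyond the scatter), where an aryl group on the carbonyl carbon likewise replaced the (6-chlorohexyl)amino group and the number fell sharply. The smaller step of a 2.7-fold lower number from compound 1 to compound 3 (0.43 log units; beyond the scatter) shows that the 3-bromophenyl amide also sits below the methoxymethyl amide. Since compound 4 is again an aryl amide of the shared core, a large downward step is expected in this assay, roughly a 48-fold lower number from compound 2 to compound 4 (1.68 log units; beyond the scatter). For compound 4 the estimated value is 100 nM, with a range from 30 nM to 400 nM.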

Compound 4, half-maximal effective concentration: > 10000 nM
Compound 4 gave a limit, no number (the forecaster's own chance of this, stated with the estimate: 5%); at least 100-fold (2.00 log units) between middle value and limit.
By their numbers in this assay, from the lowest: compound 3; then compound 1; then compound 2. At a limit, above all of these: compound 4.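

In this assay compound 4 gave no number, only a limit: the limit of > 10000 nM in this assay, at which 1 of the 4 values shown sits.

This shows that an aryl group on the carbonyl carbon does not by itself bring a low number, for exchanging 3-bromophenyl for 4-(trifluoromethoxy)phenyl gives an at least 120-fold higher number from compound 3 to compound 4 (2.09 log units; beyond the scatter). The 4-(trifluoromethoxy)phenyl amide also stands on the high side of both non-aryl compounds, with an at least 46-fold higher number from compound 1 to compound 4 (1.67 log units; beyond the scatter) and an at least 2.0-fold higher number from compound 2 to compound 4 (0.31 log units; beyond the scatter), so replacing (6-chlorohexyl)amino with an aryl group can move the number in either direction.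

The compounds shown leave open whether this gap follows the bromine or the trifluoromethoxy group, or the place of each on the phenyl ring. A 4-bromophenyl amide, a 3-(trifluoromethoxy)phenyl amide and a plain phenyl amide would separate these possibilities.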